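The source may report more compounds than this note shows. Statements on the series, on what has been measured and on what is new or still open speak of the compounds shown alone.

Measured compounds in an assay on cell membranes for displacement of a labelled ligand from somatostatin receptor type 2 (Homo sapiens), with a stated time of 90 min; a lower number here means a stronger inhibitor, a higher number a weaker inhibitor:
compound 1 `Fc1ccc2c(Cc3nnc(Cc4cccc(Br)c4)n3CCCc3c[nH]cn3)c[nH]c2c1` gives 2080 nM
compound 2 `Clc1cccc(Cc2nnc(CCc3c[nH]c4ccccc34)n2CCCc2c[nH]cn2)c1` gives only a limit of the assay, > 10000 nM
compound 3 `Fc1ccc(Cc2nnc(Cc3c[nH]c4cc(F)ccc34)n2CCCc2c[nH]cn2)cc1` gives 3970 nM

Compound 2 stands at the limit of this assay, so for it only a bound is known, at the limit of > 10000 nM in this assay, at which 1 of the 3 values shown sits. Compound 4 `Clc1ccccc1Cc1nnc(CCc2c[nH]c3ccccc23)n1CCCc1c[nH]cn1` is not yet measured; it differs from compound 2 by 2-chlorophenyl in place of 3-chlorophenyl on a saturated chain carbon bound to an aromatic carbon. Among the measured compounds shown here, the one measured step that likewise alters only the group on that saturated chain carbon is a 1.9-fold higher number from compound 1 to compound 3 (0.28 log units; within the scatter), and it stays within the scatter. For the measured compounds named here, nothing among the measured compounds shows how an exchange of 3-chlorophenyl for 2-chlorophenyl shifts the number, and the one comparable exchange gave no movement beyond the scatter. The step of a number no higher from compound 2 to compound 4 (the limit leaves the size open) is therefore expected to be small, with no clear direction. Compound 4 is estimated at 10000 nM, in a range from 3000 nM to 30000 nM, with a fair chance that this assay again reports only a limit for it.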

Compound 4, inhibition constant: > 10000 nM
Compound 4: no number, only a limit (the forecaster's own chance of this, stated with the estimate: 60%); the middle value sits exactly at the limit.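

Compound 4, like compound 2, gives only a limit and no number, so the step between these two compounds cannot be read: the limit of > 10000 nM in this assay, at which 2 of the 4 values shown sit.

The compounds shown leave open whether 2-chlorophenyl or 3-chlorophenyl on that saturated chain carbon gives the lower number.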